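The compounds below may be only part of what the source reports. "The series", "measured", "known", "first", "only" and "open" are said of these compounds alone.

Measured so far in a functional assay on MCF7 cells (Homo sapiens) for cytotoxicity, read by MTT assay, with a stated time of 72 h; a lower number here means a stronger inhibitor, a higher number a weaker inhibitor
compound 1 `O=C(N/N=C/c1ccc(F)cc1)Nc1cc2c(Nc3ccc(F)c(Cl)c3)ncnc2cc1O[C@H]1CCOC1` gives 28200 nM
compound 2 `O=C(N/N=C/c1ccc(O)c(Br)c1)Nc1cc2c(Nc3ccc(F)c(Cl)c3)ncnc2cc1O[C@H]1CCOC1` gives 2690 nM
compound 3 `COc1cc2ncnc(Nc3ccc(F)c(Cl)c3)c2cc1NC(=O)N/N=C/c1ccc(F)cc1` gives 35100 nM

Compound 3 and compound 1 are level within the scatter and share the high end of this small set. Compound 2 at 2690 nM and compound 3 at 35100 nM lie apart by a margin beyond the scatter, with compound 2 holding the lower number.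

Compound 4 (`COc1cc2ncnc(Nc3ccc(F)c(Cl)c3)c2cc1NC(=O)N/N=C/c1ccc(F)cc1Cl`) differs from compound 3 in one place: chloro in place of hydrogen on an aromatic carbon (chloro in place of hydrogen on an aromatic carbon, 4-fluorophenyl to 2-chloro-4-fluorophenyl).

Within the data shown here, two measured steps bear on this. The change on the 4-fluorophenyl group itself, to 3-bromo-4-hydroxyphenyl, is large: a 10-fold lower number from compound 1 to compound 2 (1.02 log units; beyond the scatter) for that swap. It replaces more than a single hydrogen, however, and brings in no chloro. The swap of oxolan-3-yl for methyl, a 1.2-fold higher number from compound 1 to compound 3 (0.10 log units; within the scatter) in size, stays within the scatter.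

Among the measured compounds shown here, no measured step shows chloro alone, so no step beyond the scatter is expected in this assay here. The estimated step is a 1.3-fold lower number from compound 3 to compound 4 (0.10 log units; within the scatter) and it lies within the scatter. Compound 4 is estimated at 28000 nM with an expected range from 11000 nM to 65000 nM for the coming measurement.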

Compound 4, half-maximal inhibitory concentration: "not active" (no number reported)
Compound 4: no number reported, and the estimate cannot be compared.
By their numbers in this assay, from the lowest: compound 2; then compounds 1 and 3 (each within the scatter of the next).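

Among these compounds, compound 4 is reported as "not active" without a number in this assay, and no step from compound 3 to compound 4 can be read. The compounds shown leave open what chloro alone does in the change from 4-fluorophenyl to 2-chloro-4-fluorophenyl. No evidence at hand bears on this result.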